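Benzyl ether variation and cytotoxicity in one series

The source may report more compounds than this note shows. Statements on the series, on what has been measured and on what is new or still open speak of the compounds shown alone.

Two compounds of this series have been run in an ADME assay on MT4 cells (Homo sapiens) for cytotoxicity, read by MTT assay, with a stated time of 5 days; on this read-out lower numbers stand for higher toxicity in this test and higher numbers for lower toxicity in this test. Compound 1 `N#Cc1ccc(Nc2nccc(OCc3cccc(Br)c3)n2)cc1` gives 221000 nM, and compound 2 `COc1ccccc1COc1ccnc(Nc2ccc(C#N)cc2)n1` gives 8900 nM. Going by the values given here, compound 2 stands lowest of the two numbers; its nearest neighbour is compound 1, which lies a 25-fold lower number from compound 1 to compound 2 (1.40 log units; beyond the scatter) away, the sole measured step and a large one, covering the exchange of 3-bromophenyl for 2-methoxyphenyl on a saturated chain carbon bound to an oxygen on an aromatic ring.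

Compound 3 `N#Cc1ccc(Nc2nccc(OCc3cccc(C#N)c3)n2)cc1` is not yet measured. It differs from compound 2 as follows: 3-cyanophenyl in place of 2-methoxyphenyl on a saturated chain carbon bound to an oxygen on an aromatic ring. The same position of the molecule is altered as in the step from compound 1 to compound 2, so that step is the only one that bears here; it shows that this position moves the read-out strongly. Compound 3 carries a 3-cyanophenyl rather than the 2-methoxyphenyl of compound 2, a shift that in the known step went with a large change, so a step back toward a higher number is expected, estimated as a 6.7-fold higher number from compound 2 to compound 3 (0.83 log units; beyond the scatter). For compound 3 the value in this assay is estimated at 60000 nM, within a range of 15000 nM to 250000 nM.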

Compound 3, half-maximal cytotoxic concentration: 4100 nM
Beside the measured number, compound 3's estimate is 15-fold (1.17 log units) above it; the whole stated range lies above it.
By their numbers in this assay, from the lowest: compound 3; then compound 2; then compound 1.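

In this assay, a change of the group alone, with the 3-substituted phenyl kept, gives a 54-fold lower number from compound 1 to compound 3 (1.73 log units; beyond the scatter), so the high number of compound 1 belongs to the 3-bromophenyl group and not to 3-substitution as such. The earlier step could not show this, as it changed both the group and its number in the name. A further step, a 2.2-fold lower number from compound 2 to compound 3 (0.34 log units; beyond the scatter), is modest but beyond the scatter, and it places 3-cyanophenyl rather than 2-methoxyphenyl at the low end of the series, so among these three compounds the 3-bromophenyl group stands apart from the other two. No measurement at hand accounts for these differences.

From the compounds shown here alone, compound 2 and compound 3 differ in both the group and its number in the name, so the separate contributions of methoxy versus cyano and of ring placement remain open. Going by these compounds, how an amine or a carboxylic acid on the phenyl ring, or a longer chain in place of the saturated chain carbon, would read in this test also stays open.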